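Trifluoromethyl in place of fluoro in compound 2

A few compounds are considered here, and "the series" means these few. Any claim that something is new, unique, unknown or untested is made for them only; others in the source may bear on it.

compound 1 `CC(C)(C)c1ccc(NS(=O)(=O)c2cccc(CCCCCCNC(=O)/C=C/c3cccnc3)c2)cc1` gives 26.3 nM
compound 2 `O=C(/C=C/c1cccnc1)NCCCCCCc1cccc(S(=O)(=O)Nc2ccc(F)cc2)c1` gives 0.91 nM

Within the data shown here, in a functional assay on MCF7 cells (Homo sapiens) for inhibition, read by CCK-8 assay, with a stated time of 72 h (on this read-out higher numbers stand for weaker inhibition and lower numbers for stronger inhibition), compound 2 (0.91 nM) holds the lower of the two numbers measured so far. Compound 3 `O=C(/C=C/c1cccnc1)NCCCCCCc1cccc(S(=O)(=O)Nc2ccc(C(F)(F)F)cc2)c1` differs from it in one place: trifluoromethyl in place of fluoro on an aromatic carbon. Among the measured compounds shown here, the only measured step at this place is a 29-fold lower number from compound 1 to compound 2 (1.46 log units; beyond the scatter), a large one, with fluoro in place of tert-butyl. Trifluoromethyl was not part of that step, so it gives only a direction. A moderate rise beyond the scatter is therefore expected in this assay, smaller than that step. The expected step is a 4.4-fold higher number from compound 2 to compound 3 (0.64 log units; beyond the scatter) in all. For compound 3 the estimated value is 4 nM, with an expected range from 1.2 nM to 14 nM.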

Compound 3, half-maximal inhibitory concentration: 67.8 nM
For compound 3 the middle estimate is 17-fold (1.23 log units) below the measured one; measured number above the stated range.
By their numbers in this assay, from the lowest: compound 2; then compound 1; then compound 3.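

In this assay trifluoromethyl in place of fluoro gives a 75-fold higher number from compound 2 to compound 3 (1.87 log units; beyond the scatter) and shows that the low number of compound 2 does not extend to this other fluorine-bearing group. Trifluoromethyl in place of tert-butyl gives a 2.6-fold higher number from compound 1 to compound 3 (0.41 log units; beyond the scatter) and places both larger groups well away from fluoro, so of the three groups at this place, fluoro gives the lowest number. Nothing available explains this sharp sensitivity.

The compounds shown leave open whether a hydrogen, chloro, methoxy or amine at this place would stay close to fluoro. They also leave open how fluoro would behave elsewhere on the ring.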